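Benzylsulfanyl joined to the sugar-bearing core

The compounds below may be only part of what the source reports. "The series", "measured", "known", "first", "only" and "open" are said of these compounds alone.

Measured so far:
compound 1, `c1ccc(CSc2nc3cnsc3[nH]2)cc1`: 14000 nM
compound 2, `Cc1nsc2c1ncn2[C@H]1C[C@H](O)[C@@H](CO)O1`: > 100000 nM

Both compounds were run in a functional assay on HFF cells (Homo sapiens) for inhibition; a higher number here means a weaker inhibitor, a lower number a stronger inhibitor. Compound 1 is a weak inhibitor in this assay at 14000 nM. For compound 2 this assay reports no number, only a limit, > 100000 nM. Compound 2 therefore stands at the limit of > 100000 nM in this assay, at which 1 of the 2 values shown sits, and nothing more can be read from its result than that the inhibition is too weak to be quantified.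

Compound 3, `Cc1nsc2c1nc(SCc1ccccc1)n2[C@H]1C[C@H](O)[C@@H](CO)O1`, has not yet been measured. It differs from compound 2 in one place: benzylsulfanyl in place of hydrogen on an aromatic carbon. Among the compounds with values here, no step between two measured compounds connects these structures, so the size of the change can only be guessed. Compound 1 carries the same benzylsulfanyl group on a closely related core and gives 14000 nM, which suggests that adding this group to compound 2 could bring a quantifiable, if weak, inhibition. Compound 3 is expected to give about 40000 nM, within 8000 nM to 200000 nM. The expected step is an at least 2.5-fold lower number from compound 2 to compound 3 (0.39 log units; beyond the scatter), toward stronger inhibition, though a second limit result would not be surprising.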

Compound 3, half-maximal inhibitory concentration: > 100000 nM
Compound 3 gave a limit, no number (the forecaster's own chance of this, stated with the estimate: 45%); middle value at least 2.5-fold (0.39 log units) away from the limit.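

Compound 2 and compound 3 both end at a limit rather than a number in this assay, so no step can be read for benzylsulfanyl in place of hydrogen on an aromatic carbon: the limit of > 100000 nM in this assay, at which 2 of the 3 values shown sit.

The compounds shown leave open whether this benzylsulfanyl group changes inhibition at all on the core of compound 2.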